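Removing One Methoxy Group from Compound 2

The source may hold more compounds than are shown below. What is called first, only, known or untested is meant among the compounds shown, and "the series" means these compounds.

Compound 1 `COc1ccc(-c2cc(/C=C/C(=O)c3ccc(N)cc3)[nH]n2)cc1`: 1690 nM in a functional assay on SW-620 cells (Homo sapiens) for inhibition, read by sulforhodamine B assay, with a stated time of 48 h; on this read-out lower numbers stand for stronger inhibition of growth and higher numbers for weaker inhibition of growth
Compound 2 `COc1cc(-c2cc(/C=C/C(=O)c3ccc(N)cc3)[nH]n2)cc(OC)c1OC`: 2050 nM in this assay
Compound 3 `COc1ccc(C(=O)/C=C/c2cc(-c3cc(OC)c(OC)c(OC)c3)n[nH]2)cc1OC`: 1370 nM in this assay

Compound 2 carries the highest of the three numbers in this assay, but its gaps to compound 1 and to compound 3 both lie within the usual scatter, so no order among the three can be claimed. Compound 4 `COc1ccc(-c2cc(/C=C/C(=O)c3ccc(N)cc3)[nH]n2)cc1OC` differs from compound 2 by hydrogen in place of methoxy on an aromatic carbon. For the measured compounds named here, the only measured step, a 1.5-fold lower number from compound 2 to compound 3 (0.18 log units; within the scatter), alters the group on the carbonyl carbon, far from the place changed here, and was itself within the scatter. Compound 1, which carries fewer methoxy groups than compound 2, gives a number within the scatter of compound 2. No step beyond the scatter is therefore expected. Compound 4 is estimated at 1800 nM, with a range from 900 nM to 3600 nM, meaning an expected step of a 1.1-fold lower number from compound 2 to compound 4 (0.06 log units; within the scatter).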

Compound 4, concentration for 50% growth inhibition: 2500 nM
The estimate for compound 4 lay 1.4-fold (0.14 log units) below the measured number; measured number inside the range.
By their numbers in this assay, from the lowest: compounds 3, 1, 2 and 4 (each within the scatter of the next).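

In this assay, hydrogen in place of methoxy on this aromatic carbon gives a 1.2-fold higher number from compound 2 to compound 4 (0.09 log units; within the scatter), while methoxy in place of hydrogen at the other changed aromatic carbon gives a 1.5-fold higher number from compound 1 to compound 4 (0.17 log units; within the scatter). Across compounds 1, 2 and 4, then, adding or removing a single methoxy group on this ring leaves each step within the scatter. Nothing available explains these small steps. From the compounds shown here alone, it remains open whether a hydroxy group, an amine or a fluorine atom on this carbon would move the number beyond the scatter. Also open, going by these compounds, is what happens with no methoxy group on this ring.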